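The source may report more compounds than this note shows. Statements on the series, on what has been measured and on what is new or still open speak of the compounds shown alone.

Working notes on the series.

Compound 2 `CO[C@H]1O[C@H](CNC(=O)CN(CCOS(=O)(=O)O)C(C)=O)[C@@H](OS(=O)(=O)O)[C@H](OS(=O)(=O)O)[C@@H]1OS(=O)(=O)O` gives 280000 nM in an assay on isolated protein for binding affinity to vascular endothelial growth factor A, long form (Homo sapiens), read by surface plasmon resonance (on this read-out higher numbers stand for weaker binding and lower numbers for tighter binding), the highest of the two numbers in hand; the nearest is compound 1 `CCN(CC(=O)NC[C@H]1O[C@H](OC)[C@@H](OS(=O)(=O)O)[C@@H](OS(=O)(=O)O)[C@@H]1OS(=O)(=O)O)C(=O)CCCCC(=O)O`, which gives 104000 nM in this assay. Among the measured compounds shown here, the one measured step, a 2.7-fold higher number from compound 1 to compound 2 (0.43 log units; beyond the scatter), replaced the ((4-carboxybutyl)carbonyl)(ethyl)amino of compound 1 with acetyl(2-(sulfooxy)ethyl)amino and moved the number modestly upward.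

Compound 3 `CO[C@H]1O[C@H](CNC(=O)CN(C(C)=O)C2CCCCC2)[C@@H](OS(=O)(=O)O)[C@H](OS(=O)(=O)O)[C@@H]1OS(=O)(=O)O` is to be measured in this assay. Its change from compound 2 is cyclohexyl in place of 2-(sulfooxy)ethyl on an amide-type nitrogen. For the measured compounds named here, no measured step exchanges a 2-(sulfooxy)ethyl for a cyclohexyl on this amide-type nitrogen; the step from compound 1 to compound 2 is the only guide to how much this position tolerates, and it was modest. On that basis a step of at most modest size is expected, in either direction, and the estimate stays close to compound 2. For compound 3 the expected value is 230000 nM, with a range from 90000 nM to 600000 nM. This means an expected step of a 1.2-fold lower number from compound 2 to compound 3 (0.09 log units; within the scatter).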

Compound 3, dissociation constant: 1700000 nM
For compound 3 the middle estimate is 7.4-fold (0.87 log units) below the measured one, outside the stated range (above it).
By their numbers in this assay, from the lowest: compound 1; then compound 2; then compound 3.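

In this assay, the nitrogen substituent is shown to matter when no sulfooxy group is carried there: cyclohexyl in place of 2-(sulfooxy)ethyl gives a 6.1-fold higher number from compound 2 to compound 3 (0.78 log units; beyond the scatter). The wider exchange of the whole amino group gives a 16-fold higher number from compound 1 to compound 3 (1.21 log units; beyond the scatter), the only step of the series printed as large, and among these three compounds the one with neither a sulfooxy nor a carboxy group in this part of the molecule has the highest number. Nothing at hand accounts for these shifts.

The compounds shown leave open whether the rise follows the loss of the sulfooxy group or the arrival of the ring. A 2-hydroxyethyl group or an open hexyl chain on the amide-type nitrogen would separate the two.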